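This account rests on a few compounds, and the source may have more. Where it says the series, first, only, none or still open, it means among the compounds named here.

Three compounds of one series share a core and differ only in the group on the aromatic carbon next to the ring nitrogen. Compound 1 `CC(C(=O)NCc1ccc(C(F)(F)F)nc1-c1ccccc1)c1ccc(NS(C)(=O)=O)c(F)c1` carries a phenyl there, and in an assay on CHO cells for antagonist activity at transient receptor potential cation channel subfamily V member 1 (Homo sapiens), read by FLIPR (on this read-out lower numbers stand for stronger inhibition and higher numbers for weaker inhibition), compound 1 gives 6.4 nM. Compound 2 `CC(C(=O)NCc1ccc(C(F)(F)F)nc1-c1ccc(Cl)c(Cl)c1)c1ccc(NS(C)(=O)=O)c(F)c1` carries a 3,4-dichlorophenyl; in this assay compound 2 gives 0.9 nM, with a 7.1-fold lower number from compound 1 to compound 2 (0.85 log units; beyond the scatter). Compound 3 `CC(C(=O)NCc1ccc(C(F)(F)F)nc1-n1ccnc1)c1ccc(NS(C)(=O)=O)c(F)c1` carries a 1H-imidazol-1-yl, and in this assay compound 3 gives 36.1 nM, the highest of the three numbers; the step of a 5.6-fold higher number from compound 1 to compound 3 (0.75 log units; beyond the scatter) and the step of a 40-fold higher number from compound 2 to compound 3 (1.60 log units; beyond the scatter) both place it well beyond the scatter from the other two.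

Compound 4 `CC(C(=O)NCc1ccc(C(F)(F)F)nc1Cc1ccccc1)c1ccc(NS(C)(=O)=O)c(F)c1` is not yet measured. It differs from compound 3 by benzyl in place of 1H-imidazol-1-yl on an aromatic carbon. Among the measured compounds shown here, the steps that bear on this change are those in which the 1H-imidazol-1-yl entered: a 5.6-fold higher number from compound 1 to compound 3 (0.75 log units; beyond the scatter) and a 40-fold higher number from compound 2 to compound 3 (1.60 log units; beyond the scatter). Both carry a five-membered ring with two hetero atoms in, and both raise the number. Removing that ring again in favour of a six-membered ring of carbon only, as in compound 4, is therefore expected to lower the number, by a step of the order seen between compound 1 and compound 3, expressed as a 4.0-fold lower number from compound 3 to compound 4 (0.60 log units; beyond the scatter). For compound 4 in this assay the expected value is 9 nM, within a range from 3 nM to 35 nM.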

Compound 4, inhibition constant: 141 nM
Compound 4: middle estimate off by 16-fold (1.19 log units), on the low side, and the stated range ends below it.
By their numbers in this assay, from the lowest: compound 2; then compound 1; then compound 3; then compound 4.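

In this assay, a single carbon placed between the aromatic ring and the position next to the ring nitrogen separates two otherwise matching compounds by a large step (a 22-fold higher number from compound 1 to compound 4 (1.34 log units; beyond the scatter)), so at this place the phenyl ring and the benzyl group are far from interchangeable. A six-membered aromatic ring of carbon only therefore does not ensure a low number here: the benzyl compound stands above the imidazolyl compound (a 3.9-fold higher number from compound 3 to compound 4 (0.59 log units; beyond the scatter)), and the gap to the dichlorophenyl compound is now the widest in the series (a 160-fold higher number from compound 2 to compound 4 (2.19 log units; beyond the scatter)), with all three groups that join their ring directly to the core giving lower numbers than benzyl. No measurement at hand accounts for this result.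

The compounds shown leave open whether the dichloro substitution that lowers the number on phenyl would do the same on benzyl, as a 3,4-dichlorobenzyl group would show. They also leave open whether the rise follows the methylene link itself or would recur with an oxygen or an amine nitrogen in its place, as in phenoxy or anilino.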